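Methoxy in place of dimethylamino: an expected modest step

This account rests on a few compounds, and the source may have more. Where it says the series, first, only, none or still open, it means among the compounds named here.

Compound 1 `COc1cc(-c2ccnc3cc(-c4c[nH]c5ccccc45)nn23)cc(OC)c1OC`: 35 nM
Compound 2 `COc1cc(-c2ccnc3cc(-c4ccc5c(ccn5C)c4)nn23)cc(OC)c1OC`: 39 nM
Compound 3 `COc1cc(-c2ccnc3cc(-c4ccc(N(C)C)cc4)nn23)cc(OC)c1OC`: 2050 nM

These values come from a functional assay on HCT-116 cells (Homo sapiens) for inhibition, read by CCK-8 assay, with a stated time of 48 h; on this read-out higher numbers stand for weaker inhibition and lower numbers for stronger inhibition. Compound 3, at 2050 nM, has the highest number of the three and is the weakest inhibitor here, with its steps to both others beyond the scatter. Compound 4 `COc1ccc(-c2cc3nccc(-c4cc(OC)c(OC)c(OC)c4)n3n2)cc1` differs from it in one place: methoxy in place of dimethylamino on an aromatic carbon. This puts methoxy in place of dimethylamino on an aromatic carbon, para to a large group.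

Among the measured compounds shown here, no measured step makes this exchange. The nearest evidence is a 59-fold higher number from compound 1 to compound 3 (1.77 log units; beyond the scatter) and a 53-fold higher number from compound 2 to compound 3 (1.72 log units; beyond the scatter). Both are large, but each replaces a whole indolyl group with 4-(dimethylamino)phenyl, a bigger change than the one at issue. A modest move towards a lower number is therefore expected, though the direction is uncertain. The expected change is a 2.6-fold lower number from compound 3 to compound 4 (0.41 log units; beyond the scatter). Compound 4 is estimated at 800 nM, with an expected range from 150 nM to 4000 nM.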

Compound 4, half-maximal inhibitory concentration: 404 nM
For compound 4 the middle estimate is 2.0-fold (0.30 log units) above the measured one, and the stated range covers the measured number.
By their numbers in this assay, from the lowest: compounds 1 and 2 (each within the scatter of the next); then compound 4; then compound 3.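

On the aromatic carbon para to a large group, the exchange of dimethylamino for methoxy alone moves the number in this assay beyond the scatter (a 5.1-fold lower number from compound 3 to compound 4 (0.71 log units; beyond the scatter)). The earlier compounds shown here changed the whole aryl group at once, so they could not show that this one substituent matters on its own. Even so, 4-methoxyphenyl leaves a large gap to both indolyl groups (a 10-fold higher number from compound 2 to compound 4 (1.02 log units; beyond the scatter); a 12-fold higher number from compound 1 to compound 4 (1.06 log units; beyond the scatter)), and nothing on hand accounts for either the gain or the remaining gap.

The compounds shown leave open how a hydroxyl, a primary amine, a fluorine or a longer ether chain such as ethoxy would read at this place. They also leave open whether 4-methoxyphenyl would keep its lead over 4-(dimethylamino)phenyl on a different core.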